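The compounds below may be only part of what the source reports. "The series", "measured", "known", "first", "only" and "open" are said of these compounds alone.

Of the compounds shown here, two sharing one core have been tested in a functional assay on MGC-803 cells (Homo sapiens) for cytotoxicity, read by MTT assay, with a stated time of 48 h; on this read-out higher numbers stand for weaker inhibition and lower numbers for stronger inhibition. Compound 1 (`CC1=NN(C(=O)COc2ccc(Cl)cc2)C(c2ccccc2O)C1`) is recorded there as "not active" (no number reported), with no number given. Going by the values given here, compound 2 (`CC1=NN(C(=O)CN2CCCCC2)C(c2ccccc2O)C1`) gives 4310 nM, the only number so far, so it cannot yet be ranked against another value. Compound 3 (`CC(=O)Oc1ccccc1C1CC(C)=NN1C(=O)CN1CCCCC1`) has not yet been measured. It departs from compound 2 by a single change: acetyl in place of hydrogen on an oxygen on an aromatic ring, or hydroxy to acetoxy. Among the compounds with values here, no measured pair shows what such a change does, so the data offer no direction. The expectation therefore stays close to compound 2 at 4310 nM. The expected 1.1-fold lower number from compound 2 to compound 3 (0.03 log units; within the scatter) is no larger than the usual scatter. For compound 3 the estimated value is 4000 nM, with an expected range of 1500 nM to 12000 nM.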

Compound 3, half-maximal inhibitory concentration: 4890 nM
Beside the measured number, compound 3's estimate is 1.2-fold (0.09 log units) below it, within the range that was stated.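

In this assay acetyl in place of hydrogen on an oxygen on an aromatic ring gives a 1.1-fold higher number from compound 2 to compound 3 (0.05 log units; within the scatter) and so the hydroxy and acetoxy forms cannot be told apart on this read-out. Going by these compounds alone, this is the first measured pair at this position, and it shows that, in this one pair, the hydrogen on that oxygen can be replaced by acetyl with the number staying within the scatter. Nothing available explains why the two compounds read alike.

As far as these compounds go, it remains open whether other groups on that oxygen, such as methyl or benzoyl, or an amine-bearing chain, would also stay within the scatter. From the compounds shown here alone, it is equally open whether the same change would alter the result for compound 1 with its "not active" (no number reported) entry in this assay.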